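The source may report more compounds than this note shows. Statements on the series, on what has been measured and on what is new or still open speak of the compounds shown alone.

Working notes on the series. Among the measured compounds shown here, compound 2 `C#CCN(CCCCOc1ccc2ccc(=O)oc2c1)Cc1ccc(C)cc1` stands highest of the two numbers so far in an assay on isolated protein for inhibition of Amine oxidase [flavin-containing] B (Homo sapiens), read by fluorescence and Amplex Red, with stated times of 15 min and 20 min; a higher number here means a weaker inhibitor, a lower number a stronger inhibitor: compound 2 gives 1680 nM, and its nearest neighbour compound 1 `C#CCN(CCCCOc1ccc2ccc(=O)oc2c1)Cc1ccc(OC)cc1` gives 1130 nM. For the measured compounds named here, the only step between measured compounds, a 1.5-fold higher number from compound 1 to compound 2 (0.17 log units; within the scatter), is a swap of methyl for methoxy on an aromatic carbon and lies within the scatter.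

Compound 3 `C#CCN(CCCCOc1ccc2ccc(=O)oc2c1)Cc1ccc(F)c(F)c1` is not yet measured. It differs from compound 2 by 3,4-difluorophenyl in place of 4-methylphenyl on a saturated chain carbon bound to an amine nitrogen. Going by the values given here, no measured step changes that ring in this way; the single measured step, a 1.5-fold higher number from compound 1 to compound 2 (0.17 log units; within the scatter), shows that a substituent swap on the same ring moved this assay only within the scatter. On that basis no step beyond the scatter is expected from compound 2 to compound 3, a 1.1-fold lower number from compound 2 to compound 3 (0.05 log units; within the scatter), though the direction is open. Compound 3 is therefore estimated at 1500 nM, with a range from 500 nM to 4500 nM in this assay.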

Compound 3, half-maximal inhibitory concentration: 2370 nM
For compound 3 the middle estimate is 1.6-fold (0.20 log units) below the measured one, and the stated range covers the measured number.
By their numbers in this assay, from the lowest: compounds 1, 2 and 3 (each within the scatter of the next, the first and the last beyond it).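

At this ring, on a saturated chain carbon bound to an amine nitrogen, 3,4-difluorophenyl in place of 4-methylphenyl gives a 1.4-fold higher number from compound 2 to compound 3 (0.15 log units; within the scatter) in this assay, so a second kind of substituent change also stays inside the scatter. Among the compounds shown here, the new information is a 2.1-fold higher number from compound 1 to compound 3 (0.32 log units; beyond the scatter), the first step on this ring to pass the scatter, and it only just does so, with 3,4-difluorophenyl in place of 4-methoxyphenyl. No supporting data bear on why these numbers differ.

The compounds shown leave open how an unsubstituted phenyl or a 4-fluorophenyl would compare in this place, and so whether either fluorine alone accounts for the step. They also leave open what a pyridine ring or a carboxylic acid on the ring would do to the number.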